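The source may report more compounds than this note shows. Statements on the series, on what has been measured and on what is new or still open speak of the compounds shown alone.

Compound 1, `O=C(NC(=S)NNc1ncnc2ccccc12)c1ccccc1`, compound 2, `O=C(NC(=S)NNc1ncnc2ccccc12)c1ccc(Cl)cc1`, and compound 3, `COc1cc2ncnc(NNC(=S)NC(=O)c3cccc(Cl)c3)c2cc1OC`, were all tested in a functional assay on GLC82 cells (Homo sapiens) for cytotoxicity, read by MTT assay, with a stated time of 72 h; on this read-out lower numbers stand for stronger inhibition and higher numbers for weaker inhibition. Compound 1 gives 8370 nM in this assay. Compound 2 gives 6680 nM in this assay. Compound 3 gives 8370 nM in this assay.

Compounds 1 and 2 share a core and differ in one place: hydrogen in place of chloro on an aromatic carbon. That change made a step of a 1.3-fold higher number from compound 2 to compound 1 (0.10 log units; within the scatter), which lies within the scatter of repeated measurements. Compound 3 and compound 2 carry different cores, and the difference between the two cores is not broken down here; their two values lie within the scatter of each other, as do the values of compound 3 and compound 1, so no order can be read among the three.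

Compound 4, `COc1cc2ncnc(NNC(=S)NC(=O)c3ccccc3)c2cc1OC`, has not yet been measured. It differs from compound 3 in one place: hydrogen in place of chloro on an aromatic carbon. This is the same kind of change as that from compound 2 to compound 1, though not the same, since in the earlier pair the place was para to a large group and here it is meta to a large group.

On the basis of the step from compound 2 to compound 1, a 1.3-fold higher number from compound 2 to compound 1 (0.10 log units; within the scatter), the step from compound 3 to compound 4 is expected to be small, about a 1.1-fold higher number from compound 3 to compound 4 (0.05 log units; within the scatter). Compound 4 is therefore estimated to give about 9500 nM in this assay, with a likely range from 4500 nM to 20000 nM.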

Compound 4, half-maximal inhibitory concentration: 6550 nM
For compound 4 the middle estimate is 1.5-fold (0.16 log units) above the measured one; the range from low to high includes it.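

In this assay, putting hydrogen in place of the chloro of the 3-chlorophenyl group gives a 1.3-fold lower number from compound 3 to compound 4 (0.11 log units; within the scatter), and this step lies within the scatter, as does the earlier step of the same kind. Set side by side, the two steps carry opposite signs as printed, but the gap between them does not stand clear of the scatter either: the same change on two cores in this assay, a 1.3-fold higher number (0.10 log units; within the scatter) from compound 2 to compound 1 and a 1.3-fold lower number (0.11 log units; within the scatter) from compound 3 to compound 4, 1.6-fold (0.20 log units) apart, within the scatter of two such steps. This shows that the change from chloro to hydrogen gave no readable step on either core in this series, and that the two cores do not visibly disagree about it; it does not show that the step is truly the same on both, that its direction carries from one core to the other, or that the place of the chloro on the ring makes no difference, as the two pairs differ in that place as well as in the core and steps this small cannot separate those influences.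

The compounds shown leave open whether another group on this aromatic ring, such as an amine, a carboxylic acid or a longer chain, would give a step beyond the scatter on either core. They also leave open whether the chloro-to-hydrogen step would read the same way on any other cell line.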